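Double-bond configuration: from compound 2 to compound 3

The source may report more compounds than this note shows. Statements on the series, on what has been measured and on what is new or still open speak of the compounds shown alone.

For the measured compounds named here, in a functional assay on HT-29 cells (Homo sapiens) for inhibition, read by sulforhodamine B assay, with a stated time of 48 h (on this read-out higher numbers stand for weaker inhibition and lower numbers for stronger inhibition), compound 2 (`O=C1NCCN1c1ccc(/C=C\c2cccc(Cl)c2)cc1`) gives 25 nM as the only actual number so far, which makes it the sole quantified inhibitor in this small set.

Compound 1 (`CCNC(=O)Nc1ccc(/C=C/c2cccc(Cl)c2)cc1`) reads > 20000 nM in the same test, and this is a limit of the assay, not a number.

The next compound is compound 3 (`O=C1NCCN1c1ccc(/C=C/c2cccc(Cl)c2)cc1`). Its difference from compound 2 is purely one of configuration: the two compounds have the same atoms and bonds and differ only in configuration as drawn: 1 of 1 stereo elements differ; a double bond is drawn Z in compound 2 and E in compound 3 with a double bond drawn Z in compound 2 and E in compound 3.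

Going by the values given here, no measured step isolates this change, so its size cannot be read from the data and remains a judgement. With compound 2 at 25 nM as the starting point, a large loss is expected rather than a shift within the scatter. The expected move is a 200-fold higher number from compound 2 to compound 3 (2.30 log units; beyond the scatter) in the direction of weaker inhibition. A result reported only as a limit would not be surprising. Compound 3 is estimated at 5000 nM with an expected range from 400 nM to 30000 nM in this assay.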

Compound 3, half-maximal inhibitory concentration: 17000 nM
Compound 3: the middle estimate sits 3.4-fold (0.53 log units) below what was measured; low and high end bracket the measured number.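

Notes on the double bond: in this assay, the Z to E change alone gives a 680-fold higher number from compound 2 to compound 3 (2.83 log units; beyond the scatter), a large step towards weaker inhibition, which makes double-bond configuration a strong determinant of activity for this pair, with the Z form far ahead of the E form. No substituent contributes to this step, and the whole shift can be assigned to the double bond: the fact that compounds 2 and 3 differ only in the configuration as drawn

Compound 1 gives > 20000 nM, which is a limit of the assay and not a number. The exchange of (ethylcarbamoyl)amino for 2-oxoimidazolidin-1-yl on the E double bond gives an at least 1.1-fold lower number from compound 1 to compound 3 (0.07 log units; that floor lies within the scatter), so the E pair says nothing about which of these two groups is preferred: the limit of > 20000 nM in this assay, at which 1 of the 3 values shown sits.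

As far as these compounds go, whether the same preference for the Z form holds with (ethylcarbamoyl)amino in place of 2-oxoimidazolidin-1-yl remains open, since the configuration effect rests on a single pair. Also open, from the compounds shown here alone, is how far the activity of compound 2 survives when the chlorine gives way to a methoxy group or an amine, or when the ring bearing 2-oxoimidazolidin-1-yl carries a carboxylic acid.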